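Phenyl substituent exchange on a shared core: compound 3

The source may hold more compounds than are shown below. What is called first, only, known or untested is meant among the compounds shown, and "the series" means these compounds.

Measured so far in a functional assay on HCT-116 cells (Homo sapiens) for cytotoxicity, read by MTT assay, with a stated time of 48 h; on this read-out lower numbers stand for stronger inhibition and higher numbers for weaker inhibition:
compound 1 `Cc1nc2c3ccccc3ccc2c2nc3c(ccc4ccccc43)c(-c3cc([N+](=O)[O-])ccc3N)c12`: 6010 nM
compound 2 `Cc1nc2c3ccccc3ccc2c2nc3c(ccc4ccccc43)c(-c3ccccc3S)c12`: 1420 nM
compound 3 `Cc1nc2c3ccccc3ccc2c2nc3c(ccc4ccccc43)c(-c3ccc(O)cc3)c12`: not yet measured

Among the compounds with values here, compound 2 holds the lowest number of the two measured in this assay; its nearest neighbour is compound 1, and the only recorded step, a 4.2-fold lower number from compound 1 to compound 2 (0.63 log units; beyond the scatter), is modest but beyond the scatter.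

Compound 3 differs from compound 2 by 4-hydroxyphenyl in place of 2-sulfanylphenyl on an aromatic carbon. Within the data shown here, no measured pair shows this exact exchange. Among the measured compounds shown here, the one step that bears on it, a 4.2-fold lower number from compound 1 to compound 2 (0.63 log units; beyond the scatter), shows that replacing the aryl group at this position shifts this assay by a modest amount, so a change of similar size in either direction is plausible here, and a result within the scatter cannot be excluded. Given compound 2 at 1420 nM, compound 3 is expected at 2500 nM, with a range of 700 nM to 9000 nM. This estimate means a step of a 1.8-fold higher number from compound 2 to compound 3 (0.25 log units; within the scatter), expected to be small and uncertain in direction.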

Compound 3, half-maximal inhibitory concentration: 3190 nM
For compound 3 the middle estimate is 1.3-fold (0.11 log units) below the measured one; the range from low to high includes it.
By their numbers in this assay, from the lowest: compound 2; then compounds 3 and 1 (each within the scatter of the next).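

In this assay, a 2.2-fold higher number from compound 2 to compound 3 (0.35 log units; beyond the scatter): the exchange of 2-sulfanylphenyl for 4-hydroxyphenyl keeps the counts of heavy atoms, hydrogen-bond donors and hydrogen-bond acceptors the same, yet the step still lies beyond the scatter, so these counts alone do not set the number at this aromatic carbon. The second new step, a 1.9-fold lower number from compound 1 to compound 3 (0.28 log units; within the scatter), lies within the scatter, so 4-hydroxyphenyl and 2-amino-5-nitrophenyl cannot be told apart here, and among the three aryl groups only the 2-sulfanylphenyl of compound 2 stands clear of the other two. No measured evidence on the compounds offers an explanation for these differences.

The 2-sulfanylphenyl to 4-hydroxyphenyl exchange alters both the heteroatom and its place on the phenyl ring, so the series cannot yet say which of the two goes with the step; 2-hydroxyphenyl and 4-sulfanylphenyl on the shared core would separate them. Also open, going by these compounds, is how an unsubstituted phenyl or a phenyl bearing a carboxylic acid would compare at this carbon in this assay.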